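Propargyloxy analogue in the phenyl ether series

This account rests on a few compounds, and the source may have more. Where it says the series, first, only, none or still open, it means among the compounds named here.

Compounds measured so far in an assay on cells for displacement of a labelled ligand from adenosine receptor A3 (Homo sapiens), read by scintillation counting, with a stated time of 3 h; on this read-out lower numbers stand for stronger inhibition and higher numbers for weaker inhibition:
- compound 1 `CC(C)COc1ccc(-c2cn3c(=O)n(-c4ccccc4)nc3c(N)n2)cc1`: "not determined" (no result reported)
- compound 2 `Nc1nc(-c2ccc(O)cc2)cn2c(=O)n(-c3ccccc3)nc12`: 53 nM
- compound 3 `C=CCOc1ccc(-c2cn3c(=O)n(-c4ccccc4)nc3c(N)n2)cc1`: "not determined" (no result reported)

Compound 3 carries the allyloxy group on the phenyl ring; in this assay it has no single number, and compound 1, with its isobutoxy group, is in the same position. Among the compounds with values here, the only number on the shared core comes from compound 2, whose free hydroxyl gives 53 nM in this assay.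

Compound 4 `C#CCOc1ccc(-c2cn3c(=O)n(-c4ccccc4)nc3c(N)n2)cc1` differs from compound 3 by ethynyl in place of vinyl on a saturated chain carbon bound to an oxygen on an aromatic ring. Within the data shown here, no pair of measured compounds spans this or any other single change, so there is no measured step to lean on. The expectation is for no step beyond the usual scatter between compound 3 and compound 4; without a number for compound 3, the anchor is the value of compound 2 in this assay.

For compound 4 the estimated inhibition constant in this assay is 60 nM, expected to fall between 10 nM and 400 nM.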

Compound 4, inhibition constant: > 30000 nM
Compound 4 gave a limit, no number; the forecaster's own chance of this, stated with the estimate: 15%; at least 500-fold (2.69 log units) between middle value and limit.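

In this assay compound 4 gives > 30000 nM, which is a limit of the assay and not a number. Propargyl in place of hydrogen on the oxygen on the aromatic ring gives an at least 560-fold higher number from compound 2 to compound 4 (2.75 log units; beyond the scatter), the first measured change at this position and one that lies beyond the scatter, so this position does not accept every ether in place of the free hydroxyl. Among the compounds shown, compound 4 alone stands at this limit: the limit of > 30000 nM in this assay, at which 1 of the 4 values shown sits.

Going by these compounds, with no single number for compound 1 or compound 3, the steps involving them cannot be read, and whether the loss belongs to propargyl alone or to ethers at this oxygen in general stays open. Also open, on these data alone, is how a methoxy group, or a chain ending in an amine, would read on the same oxygen.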